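The compounds below may be only part of what the source reports. "The series", "measured", "known", "first", "only" and "open" are said of these compounds alone.

Measured so far:
- compound 1, `Cc1cccc(-c2noc(COc3ccc(CCC(=O)O)cc3Cl)n2)c1`: 4580 nM
- compound 2, `CCc1ccc(-c2noc(COc3ccc(CCC(=O)O)cc3)n2)cc1`: 210 nM

In a functional assay on CHO cells for agonist activity at Free fatty acid receptor 1 (Homo sapiens), read by FLIPR and calcium flux, in the presence of a further agent that is not named here (on this read-out higher numbers stand for an effect only at larger amounts of compound and lower numbers for an effect already at smaller amounts), compound 1 gives the higher of the two numbers, with 4580 nM; compound 2 gives 210 nM, and the gap between them lies beyond the scatter. The two differ in more than one place, so no single step can be read from that pair.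

Compound 3, `COc1cccc(-c2noc(COc3ccc(CCC(=O)O)cc3Cl)n2)c1`, has not been measured. It differs from compound 1 in one place: methoxy in place of methyl on an aromatic carbon. Methoxy in place of methyl on an aromatic carbon is a small change, and no measured pair in this set shows its effect. The expectation is a step of a 1.1-fold lower number from compound 1 to compound 3 (0.06 log units; within the scatter) from compound 1 to compound 3, most likely within the usual scatter and without a clear direction. For compound 3 the estimated value in this assay is 4000 nM, with a range from 1400 nM to 12000 nM.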

Compound 3, half-maximal effective concentration: 3000 nM
The estimate for compound 3 lay 1.3-fold (0.12 log units) above the measured number, and the stated range covers the measured number.
By their numbers in this assay, from the lowest: compound 2; then compounds 3 and 1 (each within the scatter of the next).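

At this place, on an aromatic carbon meta to a large group, methoxy in place of methyl gives a 1.5-fold lower number from compound 1 to compound 3 (0.18 log units; within the scatter) in this assay. For the compounds shown here, this is the first step that can be read from a single change, and it shows that going from 3-methylphenyl to 3-methoxyphenyl, with an oxygen and a hydrogen-bond acceptor entering, leaves the two numbers within the scatter of each other. No measured evidence bears on this result.

On these data alone, whether an amine, a carboxylic acid or a longer chain at this place would move the number beyond the scatter remains open. Also open, as far as these compounds go, is whether methoxy in place of methyl gives a similar step on a core without the chlorine of compound 1.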